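A few compounds are considered here, and "the series" means these few. Any claim that something is new, unique, unknown or untested is made for them only; others in the source may bear on it.

Measured so far:
compound 1, `Cc1nc(C(NC(=O)C(=O)Nc2ccc(Cl)cc2)C2CCCCN2)sc1CO` — > 22000 nM
compound 2, `Cc1nc(C(NC(=O)C(=O)Nc2ccc(C(F)(F)F)cc2)C2CCCCN2)sc1CO` — > 75500 nM

In an ADME assay on TZM-b1 cells (Homo sapiens) for cytotoxicity, read by XTT assay, with a stated time of 3 days (on this read-out higher numbers stand for lower toxicity in this test and lower numbers for higher toxicity in this test), compound 1 gives > 22000 nM, which is a limit of the assay and not a number. In this assay compound 2 gives > 75500 nM, likewise a limit. Going by the values given here, compound 2 thus stands only at a limit, and the one other value shown is a limit as well. The step that the two limits leave unreadable from compound 1 to compound 2 cannot be sized because the limit of > 22000 nM in this assay, at which 1 of the 2 values shown sits, and the limit of > 75500 nM in this assay, at which 1 of the 2 values shown sits, are both limits.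

Compound 3 is `Cc1nc(C(NC(=O)C(=O)Nc2ccc(Cl)c(F)c2)C2CCCCN2)sc1CO`, not yet measured in this assay. It differs from compound 2 by 4-chloro-3-fluorophenyl in place of 4-(trifluoromethyl)phenyl on an amide-type nitrogen. Among the compounds with values here, the single measured step concerns the same kind of exchange at the same place, read the other way, but gives no usable size or direction. The expected step is an at least 1.5-fold lower number from compound 2 to compound 3 (0.17 log units; that floor lies within the scatter), nothing beyond the scatter. For compound 3 the estimate in this assay is 50000 nM, within 20000 nM to 200000 nM, most likely reported again as a limit.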

Compound 3, half-maximal cytotoxic concentration: 58400 nM
Compound 3: middle estimate off by 1.2-fold (0.07 log units), on the low side; the measured number falls inside the stated range.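

In this assay compound 3 gives 58400 nM, the first result in this set that is a number and not a limit, so a cytotoxic concentration can be read for a halogenated phenyl at this amide-type nitrogen. The exchange of 4-(trifluoromethyl)phenyl for 4-chloro-3-fluorophenyl gives an at least 1.2-fold lower number from compound 2 to compound 3 (0.11 log units; that floor lies within the scatter), so no change beyond the scatter can be claimed for this exchange. The steps from compound 1 to compound 2 and to compound 3 cannot be read: the limit of > 22000 nM in this assay, at which 1 of the 3 values shown sits.

What the added fluoro does on the 4-chlorophenyl therefore remains unresolved. Also open, from the compounds shown here alone, is how a phenyl carrying an amine or a carboxylic acid in place of the halogens would read at this amide-type nitrogen, since only halogen-bearing groups appear here.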